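This account rests on a few compounds, and the source may have more. Where it says the series, first, only, none or still open, it means among the compounds named here.

Compound 1 `C[C@@H]1C(=O)N[C@H](Cc2ccc(F)cc2)C(=O)NCCCc2ccc(F)cc2OCCN[C@@H](C2CC2)C(=O)N1C`: 44 h
Compound 2 `CCC[C@@H]1NC[C@@H](C)Oc2ccccc2CCCNC(=O)[C@@H](Cc2ccc(F)cc2)NC(=O)[C@@H](C)N(C)C1=O`: 29 h
Compound 3 `C[C@@H]1CN[C@@H](C2CC2)C(=O)N(C)[C@H](C)C(=O)N[C@H](Cc2ccccc2)C(=O)NCCCc2ccccc2O1`: 32 h

These values come from an in vivo ADME assay on the whole organism (strain Sprague-Dawley) for metabolic stability, with Rattus norvegicus as the target; on this read-out higher numbers stand for a longer-lived compound and lower numbers for a shorter-lived compound. Compound 1 stands level with the other two, since its number lies within the usual scatter of both compound 2 and compound 3. Compound 4 `C[C@@H]1C(=O)N[C@H](Cc2ccc(F)cc2)C(=O)NCCCc2ccccc2OCCN[C@@H](C2CC2)C(=O)N1C` has hydrogen in place of fluoro on an aromatic carbon of compound 1 (hydrogen in place of fluoro on an aromatic carbon). For the measured compounds named here, no measured pair isolates a change like this one. The nearest guide is compound 3, which carries no fluoro at all and gives 32 h, though it also differs from compound 1 elsewhere. No change beyond the scatter is therefore expected. The expected shift, a 1.2-fold lower number from compound 1 to compound 4 (0.09 log units; within the scatter), stays within that scatter. For compound 4 the estimate is 36 h, with an expected range of 22 h to 58 h.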

Compound 4, half-life: 14 h
Compound 4: the middle estimate sits 2.6-fold (0.41 log units) above what was measured; measured number below the stated range.
By their numbers in this assay, from the lowest: compound 4; then compounds 2, 3 and 1 (each within the scatter of the next).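

Replacing this single fluoro with hydrogen gives a 3.1-fold lower number from compound 1 to compound 4 (0.50 log units; beyond the scatter) in this assay and is the first change in one place only among these compounds. The earlier compounds shown here differ from one another in several places, so they could not isolate this atom. The step shows that this aromatic carbon is sensitive to the swap, even though compound 4 keeps its other fluoro.

From the compounds shown here alone, whether chloro, methyl or methoxy at this carbon would behave like fluoro or like hydrogen remains open. The effect of removing the other fluoro alone is also open, and nothing shown here explains the step.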